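A few compounds are considered here, and "the series" means these few. Any claim that something is new, unique, unknown or untested is made for them only; others in the source may bear on it.

Measured compounds and their values:

compound 1 `Oc1ccc(-c2cc(-c3cccc(O)c3)nc(-c3cccc(O)c3)c2)cc1` — 2230 nM
compound 2 `Oc1cccc(-c2cc(-c3ccccc3O)nc(-c3ccccc3O)c2)c1` — 3420 nM
compound 3 `Oc1cccc(-c2cc(-c3cccc(O)c3)nc(-c3ccccc3O)c2)c1` — 50000 nM

In a functional assay on T47D cells (Homo sapiens) for cytotoxicity, read by CCK-8 assay, with a stated time of 4 days (on this read-out lower numbers stand for stronger inhibition and higher numbers for weaker inhibition), compound 2 gives the second highest of the three numbers; compound 1 lies closest, within the scatter, and compound 3 lies furthest. Compound 4 `Oc1ccccc1-c1cc(-c2ccccc2O)nc(-c2ccccc2O)c1` is not yet measured. It differs from compound 2 in one place: 2-hydroxyphenyl in place of 3-hydroxyphenyl on an aromatic carbon. Among the measured compounds shown here, the only measured step that bears on this exchange is a 15-fold higher number from compound 2 to compound 3 (1.16 log units; beyond the scatter), where a 2-hydroxyphenyl gave way to a 3-hydroxyphenyl on another aromatic carbon of the shared core. The step from compound 2 to compound 4 runs the other way, 2-hydroxyphenyl replacing 3-hydroxyphenyl, though on a different aromatic carbon, so the earlier step is a guide to direction rather than to size. On that basis a lower number is expected for compound 4 in this assay, of modest size, with the possibility that the change at this position stays within the scatter. The expected step is a 1.9-fold lower number from compound 2 to compound 4 (0.28 log units; within the scatter). For compound 4 the estimate in this assay is 1800 nM, with a range from 600 nM to 6000 nM.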

Compound 4, half-maximal inhibitory concentration: 2510 nM
Estimate against measurement, compound 4: 1.4-fold (0.14 log units) below, within the range that was stated.
By their numbers in this assay, from the lowest: compounds 1, 4 and 2 (each within the scatter of the next); then compound 3.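

At the aromatic carbon opposite the ring nitrogen, meta to two 2-hydroxyphenyl groups, the exchange of 3-hydroxyphenyl for 2-hydroxyphenyl in this assay gives a 1.4-fold lower number from compound 2 to compound 4 (0.13 log units; within the scatter), so this position accepts either hydroxyphenyl isomer without a change that can be told from the scatter. The earlier compounds shown here offered only a 15-fold higher number from compound 2 to compound 3 (1.16 log units; beyond the scatter), an exchange between the same two groups on another aromatic carbon of the shared core, and that step lies beyond the scatter. Read together, the two steps show that the effect of moving the hydroxyl depends on which carbon of the shared core carries the group, so the large step cannot be carried over to this position, and nothing at hand bears on why the two positions differ.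

The compounds shown vary only the hydroxyl placement on the aryl groups, so it remains open whether this position also accepts a 4-hydroxyphenyl alongside the two 2-hydroxyphenyl groups. Also open, as far as these compounds go, is how the number responds when the hydroxyl at this position gives way to a methoxy group, an amine or a carboxylic acid.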